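The source may report more compounds than this note shows. Statements on the series, on what has been measured and on what is new or still open speak of the compounds shown alone.

Values in a functional assay on HCT-116 cells (Homo sapiens) for inhibition, read by colorimetric assay, with a stated time of 3 days; a higher number here means a weaker inhibitor, a lower number a stronger inhibitor:
- compound 1 `C/C(=N\O)C(=O)NCCCCCC(=O)Nc1ccccc1`: > 100000 nM (a limit)
- compound 2 `O=C(CCCCCCNC(=O)C(O)(O)C(F)(F)F)Nc1nc2ccccc2o1`: 3450 nM
- compound 3 `OC(O)(c1c(F)c(F)c(-n2cc(-c3ccccc3)nn2)c(F)c1F)C(F)(F)F`: > 100000 nM (a limit)

Compound 1 has no number in this assay, only a limit. Together with compound 3, it sits at the limit of > 100000 nM in this assay, at which 2 of the 3 values shown sit. Compound 2 is the only one of the three with a true number, 3450 nM.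

The next compound to be read is compound 4 `O=C(CCCCCNC(=O)c1ccc[nH]1)Nc1ccccc1`, which keeps the rest of compound 1 and changes one group: a group of 5 heavy atoms (4 carbon, 1 nitrogen; one five-membered aromatic ring with 1 hetero atom) in place of a group of 4 heavy atoms (2 carbon, 1 nitrogen, 1 oxygen; no ring), on a carbonyl carbon. The entering group is 1H-pyrrol-2-yl, on a carbonyl carbon whose other neighbours are an amide-type nitrogen. Among the measured compounds shown here, no measured pair in this set differs in one place only, so the data give no direct size for such a change.

With compound 1 known only as a limit, any step from it remains an expectation. A modest move towards stronger inhibition is expected, and compound 4 may well be reported only as a limit too. The expected step is an at least 1.6-fold lower number from compound 1 to compound 4 (0.22 log units; that floor lies within the scatter). For compound 4 the estimated value is 60000 nM, with an expected range from 15000 nM to 150000 nM.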

Compound 4, half-maximal inhibitory concentration: > 100000 nM
Compound 4 was reported as a limit; the forecaster's own chance of this, stated with the estimate: 55%; middle value at least 1.6-fold (0.22 log units) from the limit.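

In this assay, compound 1 and compound 4 are both reported only as limits, so no step between them can be read: the limit of > 100000 nM in this assay, at which 3 of the 4 values shown sit.

From the compounds shown here alone, whether 1H-pyrrol-2-yl on the carbonyl carbon of compound 4 changes inhibition relative to the group it replaces in compound 1, and in which direction, stays open.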